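A few compounds are considered here, and "the series" means these few. Any claim that something is new, unique, unknown or untested is made for them only; others in the source may bear on it.

Working notes on the series. In a functional assay on HCT-116 cells (Homo sapiens) for inhibition, read by CCK-8 assay, with a stated time of 48 h (a lower number here means a stronger inhibitor, a higher number a weaker inhibitor), compound 2 `COc1cc(-c2ccnc3cc(-c4c[nH]c5ccccc45)nn23)cc(OC)c1OC` gives 35 nM, the lowest of the two numbers in hand; compound 1 `Cn1ccc2cc(-c3cc4nccc(-c5ccc(F)cc5)n4n3)ccc21` gives 2160 nM, a gap from compound 2 that lies well beyond the scatter. Compound 3 `Cc1ccc(-c2cc3nccc(-c4ccc(F)cc4)n3n2)cc1` returns only a limit of the assay, > 10000 nM, which is the case described by the limit of > 10000 nM in this assay, at which 1 of the 3 values shown sits. For the measured compounds named here, compounds 1 and 3 differ from compound 2 at two positions at once, so no single-point step between measured compounds is available.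

Compound 4 `COc1ccc(-c2cc3nccc(-c4cc(OC)c(OC)c(OC)c4)n3n2)cc1` is the next compound. It departs from compound 2 by 4-methoxyphenyl in place of 1H-indol-3-yl on an aromatic carbon. Going by the values given here, compound 3 is the only measured compound carrying a simple substituted phenyl at this position, and compound 3 reaches only a limit. On that basis compound 4 is expected to be a weaker inhibitor than compound 2, with the step of an 8.6-fold higher number from compound 2 to compound 4 (0.93 log units; beyond the scatter) expected to exceed the scatter. The estimate for compound 4 in this assay is 300 nM, within a range from 60 nM to 2000 nM.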

Compound 4, half-maximal inhibitory concentration: 404 nM
Compound 4: the middle estimate sits 1.3-fold (0.13 log units) below what was measured; measured number inside the range.
By their numbers in this assay, from the lowest: compound 2; then compound 4; then compound 1. At a limit, above all of these: compound 3.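

For the compounds shown here, the first single-point step falls at this aromatic carbon: in this assay, a 12-fold higher number from compound 2 to compound 4 (1.06 log units; beyond the scatter), so the result here depends strongly on the group carried at this position, and 1H-indol-3-yl outperforms 4-methoxyphenyl. A simple substituted phenyl does not abolish inhibition here, as compound 4 gives a measured 404 nM. Compound 3 differs from compound 4 in two places and returns only a limit, so it adds no readable step: the limit of > 10000 nM in this assay, at which 1 of the 4 values shown sits.

The step replaces the hydrogen-bond donor and the five-membered ring of 1H-indol-3-yl together, leaving their separate contributions unresolved. Also open, going by these compounds, are how an amine or a carboxylic acid would fare at this carbon and whether the other aryl group on the shared core can be changed.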